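Spiro core ring size and oral exposure in rat

A few compounds are considered here, and "the series" means these few. Any claim that something is new, unique, unknown or untested is made for them only; others in the source may bear on it.

Compound 1 `C=CCNC(=O)C(=O)C(CC1CC1)NC(=O)[C@@H]1CC2(CN1C(=O)[C@@H](NC(=O)NC1(CS(=O)(=O)C(C)(C)C)CCCCC1)C(C)(C)C)SCCCS2` and compound 2 `C=CCNC(=O)C(=O)C(CCC)NC(=O)[C@@H]1CC2(CN1C(=O)[C@@H](NC(=O)NC1(CS(=O)(=O)C(C)(C)C)CCCCC1)C(C)(C)C)SCCCS2` are built on one core; compound 3 `C=CCNC(=O)C(=O)C(CCC)NC(=O)[C@@H]1CC2(CN1C(=O)[C@@H](NC(=O)NC1(CS(=O)(=O)C(C)(C)C)CCCCC1)C(C)(C)C)SCCS2` and compound 4 `C=CCNC(=O)C(=O)C(CC1CC1)NC(=O)[C@@H]1CC2(CN1C(=O)[C@@H](NC(=O)NC1(CS(=O)(=O)C(C)(C)C)CCCCC1)C(C)(C)C)SCCS2` are built on another, and the difference between the two cores is not broken down here. In an ADME assay on the whole organism (plasma) for pharmacokinetics, with Rattus norvegicus as the target, at a dose of 10 mg/kg by the oral route (a lower number here means less compound in the circulation, a higher number more compound in the circulation at the dose given), compound 2 gives 1940 ng.h/mL, and compound 1 gives 1300 ng.h/mL; the change cyclopropyl in place of ethyl on a saturated chain carbon, two bonds along the chain from an amide-type nitrogen and a carbonyl carbon made a step of a 1.5-fold lower number from compound 2 to compound 1 (0.17 log units; within the scatter). In this assay compound 3 gives 424 ng.h/mL, the lowest of the three measured numbers, with both compound 1 and compound 2 beyond the scatter above it. For the measured compounds named here, compound 4 is not yet measured; it carries the change (cyclopropyl in place of ethyl on a saturated chain carbon, two bonds along the chain from an amide-type nitrogen and a carbonyl carbon), the same change as the one taken from compound 2 to compound 1, at the same place on the other core. A step of about the same size is expected from compound 3 to compound 4, namely a 1.4-fold lower number from compound 3 to compound 4 (0.15 log units; within the scatter), because a 1.5-fold lower number from compound 2 to compound 1 (0.17 log units; within the scatter) stayed within the scatter and nothing measured here points another way. Compound 4 is therefore estimated to give roughly 300 ng.h/mL in this assay, with a likely range from 120 ng.h/mL to 750 ng.h/mL.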

Compound 4, area under the concentration-time curve: 582 ng.h/mL
Estimate against measurement, compound 4: 1.9-fold (0.29 log units) below; the measured number falls inside the stated range.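

In this assay cyclopropyl in place of ethyl on a saturated chain carbon, two bonds along the chain from an amide-type nitrogen and a carbonyl carbon, gives a 1.4-fold higher number from compound 3 to compound 4 (0.14 log units; within the scatter). Set beside the earlier step on the other core, the two readings agree as far as repeated measurements can tell: the same change on two cores in this assay, a 1.5-fold lower number (0.17 log units; within the scatter) from compound 2 to compound 1 and a 1.4-fold higher number (0.14 log units; within the scatter) from compound 3 to compound 4, 2.0-fold (0.31 log units) apart, within the scatter of two such steps. This shows that for these two pairs the change stays within the scatter on both cores, and that the swap of ethyl for cyclopropyl can be carried from one core to the other without a visible shift in this assay; it does not show a real effect in either direction, and two pairs say nothing about a third core.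

Still open, on these data alone, is whether a longer chain at this place, or a chain carrying an amine or a carboxylic acid, would give a step beyond the scatter. Also open, as far as these compounds go, is whether the result seen here with cyclopropyl holds on any core other than these two.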